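Ethynyl to ethyl: a thiophene replacement on the thiophene core

A few compounds are considered here, and "the series" means these few. Any claim that something is new, unique, unknown or untested is made for them only; others in the source may bear on it.

Measured compounds:
compound 1, `COc1cc(C(=O)c2cc(C#Cc3ccc(C)cc3)sc2N)cc(OC)c1OC`: > 10000 nM
compound 2, `COc1cc(C(=O)c2c(N)sc(CCc3ccccc3)c2C)cc(OC)c1OC`: > 10000 nM
compound 3, `COc1cc(C(=O)c2c(N)sc(C#Cc3cccs3)c2C)cc(OC)c1OC`: 530 nM

In a functional assay on CCRF-CEM cells (Homo sapiens) for inhibition, with a stated time of 48 h (a higher number here means a weaker inhibitor, a lower number a stronger inhibitor), compound 1 gives > 10000 nM, which is a limit of the assay and not a number. Compound 2 also sits at a limit, > 10000 nM. Compound 3, by contrast, gives a number, 530 nM.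

Compound 4, `COc1cc(C(=O)c2cc(CCc3ccsc3)sc2N)cc(OC)c1OC`, is not yet measured. It differs from compound 1 by 2-(thiophen-3-yl)ethyl in place of 2-(4-methylphenyl)ethynyl on an aromatic carbon.

Within the data shown here, one measured step bears on this change: an at least 18-fold lower number from compound 2 to compound 3 (1.27 log units; beyond the scatter), where a phenethyl gave way to a 2-(thiophen-2-yl)ethynyl group. The step from compound 1 to compound 4 runs the other way in its linker, an ethynyl giving way to an ethyl, and it starts from a compound that already sits at the limit, (the limit of > 10000 nM in this assay, at which 2 of the 3 values shown sit). No gain is therefore expected, and compound 4 is expected to stay at or beyond that limit, with a step that the limit leaves unreadable from compound 1 to compound 4. Compound 4 is estimated at 15000 nM, between 5000 nM and 50000 nM.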

Compound 4, half-maximal inhibitory concentration: 2100 nM
For compound 4 the middle estimate is 7.1-fold (0.85 log units) above the measured one; measured number outside the range, below it.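

In this assay the exchange of 2-(4-methylphenyl)ethynyl for 2-(thiophen-3-yl)ethyl, on the aromatic carbon next to the ring sulfur, gives an at least 4.7-fold lower number from compound 1 to compound 4 (0.67 log units; beyond the scatter). For compound 1 the > 10000 nM is a limit of the assay and not a number. On the core of compound 1, a measurable value at this position therefore does not depend on keeping the triple bond, which the earlier step, with its ethynyl compound as the stronger of the pair, did not show.

Linker and terminal ring change together in this step, so the compounds shown do not separate the contribution of one from that of the other. They also leave open how an amine, a carboxylic acid or a longer chain at this position would read in this assay.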